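Biphenyl amides at the alpha3/beta4 receptor: swapping a ring nitrogen

A few compounds are considered here, and "the series" means these few. Any claim that something is new, unique, unknown or untested is made for them only; others in the source may bear on it.

Compound 1, `O=C(NCc1cccc2ccccc12)c1ccccc1-c1ccccc1`: > 100000 nM
Compound 2, `[N-]=[N+]=NCCCN1CCCC(COC(=O)c2ccccc2-c2ccccc2)C1`: 1820 nM
Compound 3, `O=C(Nc1ccccn1)c1ccccc1-c1ccccc1`: 17500 nM

In an in vitro functional assay on HEK ts201 cells for antagonist activity at Neuronal acetylcholine receptor; alpha3/beta4 (Homo sapiens), read by fluorescence and calcium flux (on this read-out lower numbers stand for stronger inhibition and higher numbers for weaker inhibition), compound 1 gives only a limit, (the limit of > 100000 nM in this assay, at which 1 of the 3 values shown sits), not a number. Of the two numbers measured, compound 3 has the higher one; compound 2 gives a lower number in this assay, and the gap between them lies beyond the scatter. Compound 4 is `O=C(Nc1ccccc1)c1ccccc1-c1ccccc1`, so far unmeasured; it differs from compound 3 in one place: phenyl in place of pyridin-2-yl on an amide-type nitrogen. Among the compounds with values here, no measured pair shows this kind of change, so the expected step from compound 3 to compound 4 is a 1.1-fold higher number from compound 3 to compound 4 (0.06 log units; within the scatter), small and within the scatter, with no clear direction. Compound 4 is therefore estimated at 20000 nM, between 5000 nM and 80000 nM.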

Compound 4, half-maximal inhibitory concentration: 10700 nM
For compound 4 the middle estimate is 1.9-fold (0.27 log units) above the measured one; the measured number falls inside the stated range.
By their numbers in this assay, from the lowest: compound 2; then compounds 4 and 3 (each within the scatter of the next). At a limit, above all of these: compound 1.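

Within the data shown here, this is the first measured step at this amide-type nitrogen: in this assay there is a 1.6-fold lower number from compound 3 to compound 4 (0.21 log units; within the scatter) when phenyl stands in place of pyridin-2-yl. For this pair, then, the ring nitrogen of pyridin-2-yl can go without a difference beyond the scatter. Nothing measured here explains why the two rings read alike. The compounds shown leave open how a cyclohexyl ring on this nitrogen would read, or a phenyl ring carrying an amine.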